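A few compounds are considered here, and "the series" means these few. Any claim that something is new, unique, unknown or untested is made for them only; others in the source may bear on it.

In a functional assay on MIA PaCa-2 cells (Homo sapiens) for cytotoxicity, read by MTT assay, with a stated time of 72 h (a higher number here means a weaker inhibitor, a lower number a stronger inhibitor), two compounds that share one core have been measured so far. Compound 1 `COC1=CC(=O)c2c(COc3ccccc3)c(C)n(C)c2C1=O`, with a phenyl group on the oxygen, gives 409 nM. Compound 2 `COC1=CC(=O)c2c(COc3ccccn3)c(C)n(C)c2C1=O`, with pyridin-2-yl in that place, gives 2390 nM, the higher of the two numbers and so the weaker inhibitor. Compound 3 `COC1=CC(=O)c2c(COc3cccnc3)c(C)n(C)c2C1=O` keeps the core and changes only the ring on that oxygen: pyridin-3-yl in place of pyridin-2-yl on an oxygen on a saturated carbon. Within the data shown here, only one measured step bears on this change, namely a 5.8-fold higher number from compound 1 to compound 2 (0.77 log units; beyond the scatter). Among the measured compounds shown here, that step shows that exchanging a phenyl for a pyridin-2-yl ring can matter, but it is only a loose guide, since no measured compound yet carries pyridin-3-yl. A number somewhere between the two measured values therefore seems the most reasonable expectation, and a step larger than the measured one seems unlikely. The expected change is a 1.8-fold lower number from compound 2 to compound 3 (0.26 log units; within the scatter), a small fall in the number. For compound 3 the estimated value is 1300 nM, with an expected range from 450 nM to 3500 nM.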

Compound 3, half-maximal inhibitory concentration: 1820 nM
Compound 3: the middle estimate sits 1.4-fold (0.15 log units) below what was measured; the range from low to high includes it.
By their numbers in this assay, from the lowest: compound 1; then compounds 3 and 2 (each within the scatter of the next).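

In this assay, exchanging pyridin-2-yl for pyridin-3-yl on an oxygen on a saturated carbon gives a difference within the usual scatter (a 1.3-fold lower number from compound 2 to compound 3 (0.12 log units; within the scatter)), so these two rings cannot be told apart here, and where the ring carries its nitrogen has no visible effect on this number. The gap to the phenyl compound remains with the new ring (a 4.4-fold higher number from compound 1 to compound 3 (0.65 log units; beyond the scatter)), so among these three compounds, both pyridine rings give a clearly higher number than phenyl, meaning weaker inhibition, and none of the three goes against this. No measurement at hand explains why the phenyl ring gives the lower number.

As far as these compounds go, it remains open whether pyridin-4-yl, the third way of attaching a pyridine ring through carbon, would match the other two pyridine rings or come closer to phenyl. Also unresolved is what a phenyl ring carrying a chlorine or a methoxy group, or a saturated ring such as cyclohexyl, would give in this same place on the oxygen, and so how far the result extends beyond these three rings.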